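The compounds below may be only part of what the source reports. "The series", "measured", "known", "first", "only" and "open" are said of these compounds alone.

Compound 2, `CC#CCn1c(N2CCC[C@@H](N)C2)nc2c1c(=O)n(Cc1c(Cl)cccc1C(=O)O)c(=O)n2C`, gives > 100000 nM in an ADME assay on isolated protein for inhibition of Dipeptidyl peptidase 9 (Homo sapiens), with stated times of 15 min, 60 s and 20 min (a lower number here means a stronger inhibitor, a higher number a weaker inhibitor), and this is a limit of the assay rather than a number. Compound 1, `CC#CCn1c(N2CCC[C@@H](N)C2)nc2c1c(=O)n(Cc1ccccc1C(=O)O)c(=O)n2C`, also reaches only the limit > 100000 nM in this assay. The step that the two limits leave unreadable from compound 1 to compound 2 is therefore unreadable, since both compounds sit at the limit of > 100000 nM in this assay, at which 2 of the 2 values shown sit. Compound 3, `CC#CCn1c(N2CCC[C@@H](N)C2)nc2c1c(=O)n(Cc1cccc(F)c1C(=O)OC)c(=O)n2C`, carries 3-fluoro-2-(methoxycarbonyl)phenyl in place of 2-carboxy-6-chlorophenyl on a saturated chain carbon bound to an aromatic nitrogen. Among the compounds with values here, no measured step bears on this change, and two limits give no direction, so no movement beyond the scatter is foreseen. Compound 3 is expected to land at 100000 nM, between 30000 nM and 300000 nM, a step of a number no higher from compound 2 to compound 3 (the limit leaves the size open) that is estimated to stay within scatter.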

Compound 3, half-maximal inhibitory concentration: > 100000 nM
Compound 3 ended at the assay's limit; the forecaster's own chance of this, stated with the estimate: 70%; the middle value sits exactly at the limit.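

Compound 3 gives only a limit, as do compound 1 and compound 2, so no step among the three can be read: the limit of > 100000 nM in this assay, at which 3 of the 3 values shown sit.

The compounds shown leave open whether 3-fluoro-2-(methoxycarbonyl)phenyl in place of 2-carboxy-6-chlorophenyl changes inhibition at all.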